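Chloro for amino on the core of compound 2

The source may hold more compounds than are shown below. What is called first, only, known or untested is meant among the compounds shown, and "the series" means these compounds.

Compound 1 `CC(C)=CCC/C(C)=C/CC/C(C)=C/CC/C(C)=C/C[n+]1cn(C)c2nc[nH]/c(=N\OCc3ccccc3)c21`: 8240 nM
Compound 2 `CC(C)=CCC/C(C)=C/CC/C(C)=C/CC/C(C)=C/Cn1cnc2ncnc(N)c21`: 2780 nM

In a functional assay on cells (Homo sapiens) for cytotoxicity (a higher number here means a weaker inhibitor, a lower number a stronger inhibitor), compound 2 gives the lower of the two numbers. Compound 1 gives 8240 nM, a higher number that lies beyond the scatter. Compound 3 `CC(C)=CCC/C(C)=C/CC/C(C)=C/CC/C(C)=C/Cn1cnc2ncnc(Cl)c21` differs from compound 2 by one change: chloro in place of amino on an aromatic carbon. Going by the values given here, no measured pair shows this exchange, so its size is unknown. A modest shift, within or only just beyond the scatter, is expected, as a 1.4-fold higher number from compound 2 to compound 3 (0.14 log units; within the scatter). Compound 3 is estimated at 3800 nM, with a range from 900 nM to 16000 nM in this assay.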

Compound 3, half-maximal inhibitory concentration: 5200 nM
Compound 3: the middle estimate sits 1.4-fold (0.14 log units) below what was measured; low and high end bracket the measured number.
By their numbers in this assay, from the lowest: compounds 2, 3 and 1 (each within the scatter of the next, the first and the last beyond it).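

In this assay the amino group on this aromatic carbon of the shared core gives way to chloro, which brings no hydrogen-bond donor or acceptor, with a 1.9-fold higher number from compound 2 to compound 3 (0.27 log units; within the scatter) as the result. This single exchange therefore leaves the number within the scatter, so the amino group is not shown to be required at this position for the read-out. Nothing available explains this outcome. The compounds shown leave open whether a methoxy group, a methylamino group or plain hydrogen at this carbon would behave likewise. They also leave open whether the same exchange would give a similar step with a shorter chain on the core.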